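Shared-core series: 4-cyanophenyl in place of 2-fluorophenyl

The source may hold more compounds than are shown below. What is called first, only, known or untested is meant among the compounds shown, and "the series" means these compounds.

Measured compounds:
compound 1 `COc1cc(/C=C2\CN(C)C/C(=C\c3ccccc3F)C2=O)cc(OC)c1OC` — 4340 nM
compound 2 `CN1C/C(=C\c2ccc(C(F)(F)F)cc2)C(=O)/C(=C/c2ccccc2F)C1` — 6340 nM
compound 3 `COc1cc(/C=C2\CN(C)C/C(=C\c3cccc([N+](=O)[O-])c3)C2=O)cc(OC)c1` — 4420 nM

All three were read in a functional assay on K562 cells (Homo sapiens) for cytotoxicity, read by MTT assay, with a stated time of 24 h; a lower number here means a stronger inhibitor, a higher number a weaker inhibitor. Compound 1 gives the lowest of the three numbers; compound 3 lies nearest and compound 2 furthest, and both gaps fall within the usual scatter, so the three compounds are not separated by these numbers. For the measured compounds named here, no pair among them differs in a single place, so no step between measured compounds is available.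

Compound 4 `COc1cc(/C=C2\CN(C)C/C(=C\c3ccc(C#N)cc3)C2=O)cc(OC)c1OC` has not yet been measured in this assay. It differs from compound 1 as follows: 4-cyanophenyl in place of 2-fluorophenyl on a double-bonded chain carbon bound to a double-bonded ring carbon. Compounds 1, 2 and 3 carry different aryl groups yet give numbers within the scatter of one another, so this change is expected to produce no step beyond the scatter, in either direction. The expected step is a 1.0-fold higher number from compound 1 to compound 4 (0.02 log units; within the scatter). Compound 4 is therefore expected at 4500 nM, between 1800 nM and 11000 nM.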

Compound 4, half-maximal inhibitory concentration: 4290 nM
Compound 4: the middle estimate sits 1.0-fold (0.02 log units) above what was measured; measured number inside the range.
By their numbers in this assay, from the lowest: compounds 4, 1, 3 and 2 (each within the scatter of the next).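

The exchange of 2-fluorophenyl for 4-cyanophenyl gives the series its first comparison in which only one place differs: a 1.0-fold lower number from compound 1 to compound 4 (0.01 log units; within the scatter) in this assay is a step that stays within the scatter. For the compounds shown here, with the rest of compound 1 held fixed, this position on a double-bonded chain carbon bound to a double-bonded ring carbon therefore shows no response to this one aryl change, which the earlier comparisons, each differing in more than one place, could not show. No measurement at hand accounts for this result. Going by these compounds, whether the position also tolerates a non-aryl group, such as an amine, a carboxylic acid or a longer chain, remains open. Also open, on these data alone, is whether the same exchange gives a similar step with the other aryl groups seen in compound 2 and compound 3.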